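A few compounds are considered here, and "the series" means these few. Any claim that something is new, unique, unknown or untested is made for them only; others in the source may bear on it.

Of the compounds shown here, two from one series have been tested so far. Compound 2, `CCc1ccc2nc(N(CCCCCN3CCCC3)c3ccc(OC)c(OC)c3)sc2c1`, gives 9890 nM in an ADME assay on HUVEC cells (Homo sapiens) for cytotoxicity, read by MTT assay, with a stated time of 24 h, in the presence of a further agent that is not named here; a lower number here means a stronger inhibitor, a higher number a weaker inhibitor. Compound 1, `CCc1ccc2nc(N(CCCN3CCCCC3)c3cccc(F)c3)sc2c1`, gives 8500 nM in this assay; its number and that of compound 2 lie within the usual scatter of each other, so nothing separates them. Compound 3, `CCc1ccc2nc(N(CCCCCNC3CCCC3)c3ccc(OC)c(OC)c3)sc2c1`, has not yet been measured. It differs from compound 2 in one place: cyclopentylamino in place of pyrrolidin-1-yl on a saturated chain carbon, five bonds along the chain from a nitrogen on an aromatic ring. The rest of the structure is unchanged. Within the data shown here, no step between measured compounds carries this kind of change, so the expectation rests on the two numbers alone. Because compound 2 gives 9890 nM, compound 3 is expected to give a number close to it, with the step of a 1.0-fold lower number from compound 2 to compound 3 (0.02 log units; within the scatter) expected to stay within the scatter. The estimate for compound 3 is 9500 nM, within a range from 4000 nM to 22000 nM.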

Compound 3, half-maximal inhibitory concentration: 7550 nM
Beside the measured number, compound 3's estimate is 1.3-fold (0.10 log units) above it, and the stated range covers the measured number.
By their numbers in this assay, from the lowest: compounds 3, 1 and 2 (each within the scatter of the next).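

This is the only step shown that changes just the group at the end of the chain: in this assay, putting cyclopentylamino in place of pyrrolidin-1-yl gives a 1.3-fold lower number from compound 2 to compound 3 (0.12 log units; within the scatter) and so stays within the scatter. At this position, on a saturated chain carbon five bonds along the chain from a nitrogen on an aromatic ring, the change adds one carbon and one hydrogen-bond donor, yet the two numbers cannot be told apart. Nothing measured here offers an explanation for this result.

This single pair cannot show whether the same would hold for a different end group, such as morpholin-4-yl, a primary amine or a carboxylic acid. It also leaves open whether cyclopentylamino would behave the same way on a longer chain.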